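Trimming a Decyl Chain Down to a Hydroxyethyl Group

A few compounds are considered here, and "the series" means these few. Any claim that something is new, unique, unknown or untested is made for them only; others in the source may bear on it.

Measured so far:
- compound 2, `CCCCCCCCCCc1cn(C[C@H](O)[C@H]2OC(=O)C(OCc3ccccc3)=C2OCc2ccccc2)nn1`, gives 80 nM in a functional assay on MCF7 cells (Homo sapiens) for antiproliferative activity, read by MTT assay, with a stated time of 72 h; on this read-out higher numbers stand for weaker inhibition and lower numbers for stronger inhibition
- compound 1, `O=C1O[C@H]([C@@H](O)Cn2cc(-c3cc(C(F)(F)F)cc(C(F)(F)F)c3)nn2)C(OCc2ccccc2)=C1OCc1ccccc1`, gives 45900 nM in this assay

Both compounds share the same core and differ only in the group carried on the triazole ring. Compound 2 stands at the lowest number of the two, and the gap to compound 1 is far beyond the usual scatter of this measurement, so compound 2 is clearly the stronger inhibitor of the pair.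

Compound 3, `O=C1O[C@H]([C@@H](O)Cn2cc(CCO)nn2)C(OCc2ccccc2)=C1OCc1ccccc1`, follows from compound 2 by one change: hydroxy in place of octyl on a saturated chain carbon, two bonds along the chain from an aromatic carbon. The long decyl chain that marks compound 2 is thus cut back to a short 2-hydroxyethyl group.

Within the data shown here, with no directly comparable pair measured, the size of this step has to be judged from the two known values alone. Because compound 1, which also lacks the long chain, gives 45900 nM, a large loss in this assay is expected from compound 2 to compound 3, estimated as a 380-fold higher number from compound 2 to compound 3 (2.57 log units; beyond the scatter). Compound 3 is therefore expected to give about 30000 nM, within a range of 5000 nM to 100000 nM.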

Compound 3, half-maximal inhibitory concentration: 63400 nM
Beside the measured number, compound 3's estimate is 2.1-fold (0.32 log units) below it, and the stated range covers the measured number.
By their numbers in this assay, from the lowest: compound 2; then compounds 1 and 3 (each within the scatter of the next).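

In this assay, putting hydroxy in place of octyl on a saturated chain carbon, two bonds along the chain from an aromatic carbon, gives a 790-fold higher number from compound 2 to compound 3 (2.90 log units; beyond the scatter), so activity depends strongly on what this position carries. Compound 3 and compound 1 carry very different groups at this place, a 2-hydroxyethyl group and a trifluoromethyl-bearing aromatic ring, yet their numbers lie within the scatter of each other, and of the three compounds only compound 2, with its decyl chain, reaches a low number. Nothing measured here gives a reason for this large loss.

This single change both shortens the chain and adds a hydroxy group, so the compounds shown cannot separate the effect of chain length from that of the hydroxy group; a plain ethyl group or a hexyl chain would help tell the two apart. As far as these compounds go, it also remains open how far the number would move with a dodecyl chain, or with a decyl chain ending in an amine or a carboxylic acid.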